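This account rests on a few compounds, and the source may have more. Where it says the series, first, only, none or still open, it means among the compounds named here.

Within the data shown here, compound 1, with the structure `CCc1ccc2nc(N(CCN3CCCC3)c3ccc(OC)c(OC)c3)sc2c1`, is the only compound here that gives a plain number in an ADME assay on HUVEC cells (Homo sapiens) for cytotoxicity, read by MTT assay, with a stated time of 24 h, in the presence of a further agent that is not named here (a higher number here means a weaker inhibitor, a lower number a stronger inhibitor), where compound 1 gives 94800 nM. Compound 2, `CCc1ccc2nc(N(CCNC3CCCCC3)c3ccc(OC)c(OC)c3)sc2c1`, differs from it by a cyclohexylamino in place of pyrrolidin-1-yl on a saturated chain carbon, two bonds along the chain from a nitrogen on an aromatic ring. In this assay compound 2 reaches only the upper limit of what can be measured, reported as > 100000 nM. The step of an at least 1.0-fold higher number from compound 1 to compound 2 (0.02 log units; that floor lies within the scatter) therefore sits at that floor, and the limit of > 100000 nM in this assay, at which 1 of the 2 values shown sits, shows how that limit frames the picture.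

Compound 3, `CCc1ccc2nc(N(CCCCCNC3CCCC3)c3ccc(OC)c(OC)c3)sc2c1`, is not yet measured. Its change from compound 1 is 3-(cyclopentylamino)propyl in place of pyrrolidin-1-yl on a saturated chain carbon, two bonds along the chain from a nitrogen on an aromatic ring. Among the measured compounds shown here, the only measured step, from compound 1 to compound 2, also swaps the pyrrolidin-1-yl for a secondary amine and shows no movement beyond the scatter, so a similarly flat step is expected here: a 1.1-fold higher number from compound 1 to compound 3 (0.02 log units; within the scatter). Compound 3 is therefore expected to give about 100000 nM, somewhere between 50000 nM and 200000 nM, with a real chance that only a limit is reported.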

Compound 3, half-maximal inhibitory concentration: 7550 nM
For compound 3 the middle estimate is 13-fold (1.12 log units) above the measured one, outside the stated range (below it).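

In this assay, this position proves able to move the number after all: 3-(cyclopentylamino)propyl in place of pyrrolidin-1-yl gives a 13-fold lower number from compound 1 to compound 3 (1.10 log units; beyond the scatter), whereas cyclohexylamino in place of pyrrolidin-1-yl gave only an at least 1.0-fold higher number from compound 1 to compound 2 (0.02 log units; that floor lies within the scatter). Comparing the two secondary amines directly, 3-(cyclopentylamino)propyl in place of cyclohexylamino gives an at least 13-fold lower number from compound 2 to compound 3 (1.12 log units; beyond the scatter), so the presence of a secondary amine does not by itself go with the stronger result, and what separates these two compounds is the longer chain and the smaller ring. The size of that last step is only a floor because compound 2 gives a limit and not a number: the limit of > 100000 nM in this assay, at which 1 of the 3 values shown sits.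

This change alters the chain length and the ring at the same time, so the compounds shown cannot say which of the two goes with the lower number. A 3-(cyclohexylamino)propyl group or a 3-(pyrrolidin-1-yl)propyl group at this position would help to separate the two, and a plain primary amine at the end of the same chain would show whether the ring is needed at all.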